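Swapping the Sulfur Substituent: From Cyclohexyl to Phenethyl

A few compounds are considered here, and "the series" means these few. Any claim that something is new, unique, unknown or untested is made for them only; others in the source may bear on it.

Three compounds share one core and differ only in the group attached to a sulfur. Compound 1 `CC(C(=O)NCc1ccc(C(F)(F)F)nc1SCCCN1CCCCC1)c1ccc(NS(C)(=O)=O)c(F)c1` gives 3 nM in an assay on CHO-K1 cells for antagonist activity at transient receptor potential cation channel subfamily V member 1 (Homo sapiens), read by FLIPR; on this read-out lower numbers stand for stronger inhibition and higher numbers for weaker inhibition. Compound 2 `CC1CCN(CCCSc2nc(C(F)(F)F)ccc2CNC(=O)C(C)c2ccc(NS(C)(=O)=O)c(F)c2)CC1` gives 2.9 nM in this assay, and the step of a 1.0-fold lower number from compound 1 to compound 2 (0.01 log units; within the scatter) shows the two are indistinguishable. Compound 3 `CC1CCC(Sc2nc(C(F)(F)F)ccc2CNC(=O)C(C)c2ccc(NS(C)(=O)=O)c(F)c2)CC1` gives 0.5 nM, the lowest of the three numbers; the steps of a 6.0-fold lower number from compound 1 to compound 3 (0.78 log units; beyond the scatter) and a 5.8-fold lower number from compound 2 to compound 3 (0.76 log units; beyond the scatter) set it apart from both.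

Compound 4 `CC(C(=O)NCc1ccc(C(F)(F)F)nc1SCCc1ccccc1)c1ccc(NS(C)(=O)=O)c(F)c1` has not been measured. It differs from compound 3 in one place: phenethyl in place of 4-methylcyclohexyl on a sulfur. Among the measured compounds shown here, the only measured steps that touch this position are those leading to compound 3, each showing a modest gain when the 4-methylcyclohexyl replaced a longer chain carrying a ring with nitrogen. For the measured compounds named here, no measured step tells how a phenethyl group behaves here. The expectation is therefore a step back toward the numbers of compound 1 and compound 2, with compound 4 expected to give 2 nM, within 0.5 nM to 8 nM, a step of a 4.0-fold higher number from compound 3 to compound 4 (0.60 log units; beyond the scatter).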

Compound 4, inhibition constant: 1.9 nM
The estimate for compound 4 lay 1.1-fold (0.02 log units) above the measured number, within the range that was stated.
By their numbers in this assay, from the lowest: compound 3; then compounds 4, 2 and 1 (each within the scatter of the next).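

The step of a 3.8-fold higher number from compound 3 to compound 4 (0.58 log units; beyond the scatter) in this assay shows that the 4-methylcyclohexyl group on this sulfur cannot be swapped for phenethyl, another carbon-only group with a six-membered ring, without losing ground. Removing the nitrogen from the chain is also not enough to match compound 3: a 1.5-fold lower number from compound 2 to compound 4 (0.18 log units; within the scatter) and a 1.6-fold lower number from compound 1 to compound 4 (0.20 log units; within the scatter) both lie within the scatter, so phenethyl reads the same as the two chains that end in a ring with nitrogen. Nothing measured here gives a reason for the edge held by compound 3.

The compounds shown leave open whether that edge goes with the saturated ring or with a ring attached directly to the sulfur. A 2-cyclohexylethyl group or a phenyl group on the sulfur would separate these two possibilities.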